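Cytotoxicity Limits and a Cyclopropyl Variant of Compound 2

The source may report more compounds than this note shows. Statements on the series, on what has been measured and on what is new or still open speak of the compounds shown alone.

Compound 1 `Cc1ccc(-c2c3c(nc(C)c2C(OC(C)(C)C)C(=O)O)CCN(Cc2ccccc2-c2ccccc2)C3)cc1`: > 40000 nM
Compound 2 `Cc1nc2c(c(-c3cc(F)c4c(c3C)CCCO4)c1[C@H](OC(C)(C)C)C(=O)O)CN(CCCc1cccc(F)c1)CC2`: > 40000 nM

In an ADME assay on MT2 cells (Homo sapiens) for cytotoxicity, read by XTT assay, with a stated time of 4 days (on this read-out lower numbers stand for higher toxicity in this test and higher numbers for lower toxicity in this test), compound 1 gives > 40000 nM, which is a limit of the test and not a number. In this assay compound 2 gives > 40000 nM, again a limit rather than a measured number. Among the measured compounds shown here, compound 2 therefore stands at the limit, together with the only other value shown: the limit of > 40000 nM in this assay, at which 2 of the 2 values shown sit. For the measured compounds named here, no step between measured compounds is available, and the two values say only that neither compound reached a measurable toxicity in this test.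

Compound 3 `Cc1nc2c(c(-c3cc(F)c4c(c3C)CCCO4)c1[C@H](OC(C)(C)C)C(=O)O)CN(CC1CC1c1ccccc1)CC2` has not yet been measured in this assay. It differs from compound 2 in one place: 2-phenylcyclopropyl in place of 2-(3-fluorophenyl)ethyl on a saturated chain carbon bound to an amine nitrogen in a ring. With both shown values at the limit, no step beyond the scatter is expected in this assay, and the estimated step is a number no higher from compound 2 to compound 3 (the limit leaves the size open). Compound 3 is expected to give about 40000 nM in this assay, within a range from 15000 nM to 40000 nM, most likely reported again only as a limit.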

Compound 3, half-maximal cytotoxic concentration: > 40000 nM
Compound 3: a limit, no number; the forecaster's own chance of this, stated with the estimate: 80%; the middle value lies on the limit itself.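

In this assay compound 3 gives > 40000 nM, a limit and not a number. Among the compounds shown here, compound 2 stands at the same limit, so no step between compound 2 and compound 3 can be read. The compounds shown leave open at what concentration any of them would become toxic in this test.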